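Aldehyde in Place of the Lactone Ring in a Diterpenoid Series

The compounds below may be only part of what the source reports. "The series", "measured", "known", "first", "only" and "open" are said of these compounds alone.

Of the compounds shown here, two from a terpenoid series have been tested in an ADME assay on RAW264.7 cells (Mus musculus) for cytotoxicity, read by luminescence and CellTiter-Glo, with a stated time of 18 h, tested at 0.1 uM; on this read-out lower numbers stand for a stronger effect and higher numbers for a weaker effect at the one concentration tested. Compound 1, with the structure `C=C1CC[C@H]2C(C)(C)CCC[C@]2(C)[C@H]1C/C=C(\CCO)C(=O)O`, carries an acid and an alcohol on its side chain, and in this assay compound 1 gives 103%. Compound 2, with the structure `C=C1CC[C@H]2C(C)(C)CCC[C@]2(C)[C@H]1C/C=C1\C=COC1=O`, closes that side chain into a five-membered lactone ring, and in this assay compound 2 gives 102%. On the numbers shown, compound 2 differs from compound 1 by an amount inside the usual scatter, so the two cannot be told apart, and neither shows a notable effect on the cells at the single concentration used.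

Compound 3, with the structure `C=C1CC[C@H]2C(C)(C)CCC[C@]2(C)[C@H]1CC=O`, has not yet been measured. It differs from compound 2 by a group of 2 heavy atoms (1 carbon, 1 oxygen; no ring) in place of a group of 7 heavy atoms (5 carbon, 2 oxygen; one five-membered non-aromatic ring with 1 hetero atom), on a saturated chain carbon bound to a saturated ring carbon. Since compound 2 gives 102%, a read-out that points to an absence of effect, the expected step of a number 2 percentage points lower from compound 2 to compound 3 (within the scatter) is none beyond the scatter. Compound 3 is therefore expected to give 100%, with a range from 88% to 112%.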

Compound 3, a percentage reported as activity, at one concentration (the size of the read-out at that concentration, not a potency): 101%
The estimate for compound 3 lay 1 percentage points below the measured number; the range from low to high includes it.
By their numbers in this assay, from the lowest: compounds 3, 2 and 1 (each within the scatter of the next).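

In this assay the formyl group, in place of the five-membered ring on a saturated chain carbon bound to a saturated ring carbon, gives a number 1 percentage points lower from compound 2 to compound 3 (within the scatter) and so leaves compound 2 and compound 3 indistinguishable. The earlier pair compared only two side chains of similar reach, one open and one closed into a ring, whereas this step removes the ring and most of the side chain's heavy atoms, leaving a far smaller group at this place with no detectable difference in the read-out. The data therefore show that, at this one concentration, neither the lactone ring nor the larger group is needed for the absence of an effect on the cells, although no measurement here gives a reason for this.

The compounds shown leave open whether an amine or a longer carbon chain at this place would also leave the read-out unaffected. With a single low concentration and no clear effect from any compound, they also leave open how these structures would behave at higher concentrations.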